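Aryl sulfonyl series: clearance read-out, fluorine removal step

The source may report more compounds than this note shows. Statements on the series, on what has been measured and on what is new or still open speak of the compounds shown alone.

Measured compounds:
compound 1 `O=S(=O)(c1cc(F)cc(F)c1)c1cnc2cc(F)ccc2c1-c1ccc(Cl)cc1`, 0.03 mL/min
compound 2 `O=S(=O)(c1cc(Cl)cc(Cl)c1)c1cnc2cc(F)ccc2c1-c1ccc(Cl)cc1`, 0.13 mL/min
compound 3 `O=S(=O)(c1ccc(F)c(F)c1)c1cnc2cc(F)ccc2c1-c1ccc(Cl)cc1`, 0.01 mL/min

In an ADME assay on microsomes from liver (Homo sapiens) for metabolic stability, tested at 2.5 uM (on this read-out lower numbers stand for slow clearance and higher numbers for fast clearance), compound 3 stands lowest of the three numbers, and its steps to both others lie beyond the scatter. The nearest is compound 1: a 3.0-fold lower number from compound 1 to compound 3 (0.48 log units; beyond the scatter). The furthest is compound 2: a 13-fold lower number from compound 2 to compound 3 (1.11 log units; beyond the scatter). Exchanging fluorine for chlorine on the same ring also moved the read-out: a 4.3-fold higher number from compound 1 to compound 2 (0.64 log units; beyond the scatter).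

Compound 4 `O=S(=O)(c1cccc(F)c1)c1cnc2cc(F)ccc2c1-c1ccc(Cl)cc1` differs from compound 3 in one place: hydrogen in place of fluoro on an aromatic carbon. Going by the values given here, none of the measured steps removes a halogen outright; they only shift halogen position or swap fluorine for chlorine, and those moves were modest to large. Taking away one fluorine from the ring that carried every measured change is therefore expected to register in this assay, most plausibly as a modest rise toward the number of compound 1, with a wide range allowed since the direct analogy is lacking.

For compound 4 the expected value is 0.025 mL/min, with a range from 0.008 mL/min to 0.08 mL/min. The expected step is a 2.5-fold higher number from compound 3 to compound 4 (0.40 log units; beyond the scatter).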

Compound 4, intrinsic clearance in a liver preparation (reported as CLH), per the amount of preparation that the assay uses: 0.98 mL/min
Estimate against measurement, compound 4: 39-fold (1.59 log units) below; measured number above the stated range.
By their numbers in this assay, from the lowest: compound 3; then compound 1; then compound 2; then compound 4.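

In this assay, hydrogen in place of fluoro on an aromatic carbon, ortho to a fluoro group and para to a large group, gives a 98-fold higher number from compound 3 to compound 4 (1.99 log units; beyond the scatter), the largest step in the set and larger than any step that only moved or exchanged halogens on this ring. The 3-fluorophenyl ring also stands apart from the other two dihalogenated rings, with a 33-fold higher number from compound 1 to compound 4 (1.51 log units; beyond the scatter) and a 7.5-fold higher number from compound 2 to compound 4 (0.88 log units; beyond the scatter), so among these four compounds, the ring carrying a single halogen gives the highest number and no compound goes against this order. The data shown offer no measurement that accounts for the size of this jump.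

Still open, from the compounds shown here alone, is whether a nitrile, a methoxy group or a trifluoromethyl group on the same aromatic carbon would keep the number near that of compound 3, or whether fluoro alone does so. Also open, going by these compounds, is whether an unsubstituted phenyl ring on the sulfonyl sulfur would climb further, or whether the steep rise ends with the first fluorine lost.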